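The compounds below may be only part of what the source reports. "The series", "measured", "known", "first", "only" and "open" are said of these compounds alone.

Measured in a functional assay on SK-BR-3 cells (Homo sapiens) for antiproliferative activity (on this read-out lower numbers stand for stronger inhibition and higher numbers for weaker inhibition), so far:
compound 1 `CC(=O)Oc1ccc(C(=O)Nc2cc3ccc(OCC4CCCN(C)C4)c(C)c3oc2=O)cc1CC=C(C)C` – 740 nM
compound 2 `CC(C)=CCc1cc(C(=O)Nc2cc3ccc(OCC4CCN(C)C4)c(C)c3oc2=O)ccc1O` – 920 nM
compound 3 `CCCN(CCC)CCCOc1ccc2cc(NC(=O)c3ccc(O)c(CC=C(C)C)c3)c(=O)oc2c1C` – > 50000 nM, a limit of this assay, not a number

Compound 3 therefore stands at the limit of > 50000 nM in this assay, at which 1 of the 3 values shown sits, and is the weakest of the three shown. Among the measured compounds shown here, the only step reaching it is an at least 54-fold higher number from compound 2 to compound 3 (1.73 log units; beyond the scatter), so the side chain on the aromatic oxygen governs the outcome strongly here. Compound 4 `CC(C)=CCc1cc(C(=O)Nc2cc3ccc(OCCCNC4CCCCC4)c(C)c3oc2=O)ccc1O` is the next member, differing from compound 3 by cyclohexylamino in place of dipropylamino on a saturated chain carbon, three bonds along the chain from an oxygen on an aromatic ring. For the measured compounds named here, no measured step tests this change directly; the one known step shows only that the dipropylamino variant loses activity. Compound 4 is expected to recover some of it, an at least 3.3-fold lower number from compound 3 to compound 4 (0.52 log units; beyond the scatter), giving an estimated 15000 nM (range 2000 nM to 60000 nM), with a real chance that this assay again reports only a limit.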

Compound 4, half-maximal inhibitory concentration: 660 nM
For compound 4 the middle estimate is 23-fold (1.36 log units) above the measured one; measured number outside the range, below it.
By their numbers in this assay, from the lowest: compounds 4, 1 and 2 (each within the scatter of the next). At a limit, above all of these: compound 3.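

In this series the group on the end of the chain decides the outcome, even though dipropylamino and cyclohexylamino have the same count of heavy atoms: in this assay, an at least 75-fold lower number from compound 3 to compound 4 (1.87 log units; beyond the scatter). Compound 3 gives a limit and not a number: the limit of > 50000 nM in this assay, at which 1 of the 4 values shown sits. An open chain ending in an amine therefore need not lose activity: a 1.4-fold lower number from compound 2 to compound 4 (0.14 log units; within the scatter).

From the compounds shown here alone, it remains open whether the ring or the hydrogen-bond donor of cyclohexylamino carries the step. Propylamino or piperidin-1-yl in place of cyclohexylamino would separate the two.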